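Swapping the chlorine position on a second aryl sulfonate core

A few compounds are considered here, and "the series" means these few. Any claim that something is new, unique, unknown or untested is made for them only; others in the source may bear on it.

Compound 1 `COc1ccccc1OS(=O)(=O)/C=C/c1cccc(Cl)c1` and compound 3 `COc1ccccc1OS(=O)(=O)/C=C/c1ccc(Cl)cc1` share one core, and compound 2 `COc1ccc(OS(=O)(=O)/C=C/c2cccc(Cl)c2)cc1` carries a second core; the difference between the two cores is not broken down here. In an assay on U2OS cells for activation of nuclear factor erythroid 2-related factor 2 (Homo sapiens), read by chemiluminescence, with a stated time of 6 h (on this read-out lower numbers stand for an effect already at smaller amounts and higher numbers for an effect only at larger amounts of compound), compound 1 gives 698 nM, compound 3 gives 1330 nM, and compound 2 gives 948 nM. The change from compound 1 to compound 3 is 4-chlorophenyl in place of 3-chlorophenyl on a double-bonded chain carbon bound to a double-bonded chain carbon, and it made a step of a 1.9-fold higher number from compound 1 to compound 3 (0.28 log units; within the scatter). Compound 4 `COc1ccc(OS(=O)(=O)/C=C/c2ccc(Cl)cc2)cc1` is not yet measured; it differs from compound 2 by 4-chlorophenyl in place of 3-chlorophenyl on a double-bonded chain carbon bound to a double-bonded chain carbon, the same change applied to the other core. For the measured compounds named here, since the step to compound 3 stayed within the usual scatter, compound 4 is expected to give roughly 1700 nM, somewhere between 800 nM and 3600 nM, which would mean an estimated step of a 1.8-fold higher number from compound 2 to compound 4 (0.25 log units; within the scatter) resting on the one earlier example.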

Compound 4, half-maximal effective concentration: 1160 nM
Compound 4: the middle estimate sits 1.5-fold (0.17 log units) above what was measured; measured number inside the range.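

In this assay, 4-chlorophenyl in place of 3-chlorophenyl gives a 1.2-fold higher number from compound 2 to compound 4 (0.09 log units; within the scatter). Set beside the same change on the core of compound 1, the two steps do not differ: the same change on two cores in this assay, a 1.9-fold higher number (0.28 log units; within the scatter) from compound 1 to compound 3 and a 1.2-fold higher number (0.09 log units; within the scatter) from compound 2 to compound 4, 1.6-fold (0.19 log units) apart, within the scatter of two such steps On these two cores, then, the change carries over as a step too small to tell from repeat-measurement noise, but this does not prove that the swap has no effect, and two pairs cannot show that it would behave the same way on a third core.

The compounds shown leave open what a nitrile or a carboxylic acid in place of the chlorine would do on either core. They also leave open whether any change at this ring gives a step beyond the scatter.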